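The source may hold more compounds than are shown below. What is called first, only, known or untested is meant among the compounds shown, and "the series" means these compounds.

The measured compounds, each with its result in a functional assay, with a stated time of 30 min; a lower number here means a stronger inhibitor, a higher number a weaker inhibitor:
compound 1, `O=C(/C=C/c1ccccc1O)CC(=O)/C=C/c1cccc(O)c1O`, gives 23000 nM;
compound 2, `O=C(/C=C/c1cccc(O)c1)CC(=O)/C=C/c1cccc(O)c1O`, gives 29000 nM;
compound 3, `O=C(/C=C/c1ccccc1O)/C=C/c1cccc(O)c1O`, gives 99000 nM.

Compound 1 and compound 2 share one core and differ only by 3-hydroxyphenyl in place of 2-hydroxyphenyl on a double-bonded chain carbon bound to a double-bonded chain carbon. That change produced a 1.3-fold higher number from compound 1 to compound 2 (0.10 log units; within the scatter), so the two cannot be ordered against each other. Compound 3 is built on a different core; how its core differs from that of compound 1 is not broken down here. Its number is the highest of the three, and its steps to both compound 1 and compound 2 are beyond the scatter.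

Compound 4, `O=C(/C=C/c1cccc(O)c1)/C=C/c1cccc(O)c1O`, has not yet been measured in this assay. It differs from compound 3 by 3-hydroxyphenyl in place of 2-hydroxyphenyl on a double-bonded chain carbon bound to a double-bonded chain carbon, which is the same change, at the same place, as that between compound 1 and compound 2. For the measured compounds named here, because the only earlier instance of this change gave a 1.3-fold higher number from compound 1 to compound 2 (0.10 log units; within the scatter), compound 4 is expected to show a step of similar size, a 1.2-fold higher number from compound 3 to compound 4 (0.08 log units; within the scatter), from compound 3. Compound 4 is accordingly estimated at 120000 nM, with a likely range from 55000 nM to 260000 nM.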

Compound 4, half-maximal inhibitory concentration: 48000 nM
Compound 4: middle estimate off by 2.5-fold (0.40 log units), on the high side, and the stated range ends above it.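

For the compounds shown here, on the core of compound 3, putting 3-hydroxyphenyl in place of 2-hydroxyphenyl gave in this assay a 2.1-fold lower number from compound 3 to compound 4 (0.31 log units; beyond the scatter), a modest step that lies just beyond the scatter, whereas the same change on the core of compound 1 gave no step that can be read. Set side by side, the two results do not differ by more than repeated measurements would allow: the same change on two cores in this assay, a 1.3-fold higher number (0.10 log units; within the scatter) from compound 1 to compound 2 and a 2.1-fold lower number (0.31 log units; beyond the scatter) from compound 3 to compound 4, 2.6-fold (0.42 log units) apart, within the scatter of two such steps

The change can therefore be said to carry from one core to the other without any demonstrable difference in its effect, but this does not prove that the effect is the same on both, and a single pair of cores supports no general rule for the series.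

The compounds shown leave open how a methoxy group or a carboxylic acid would compare with the hydroxyl on the changed ring. They also leave open whether the change would behave in the same way on a third core, for instance one with a longer chain joining the two rings.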